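Aryl to pyrazinyl swap on a piperazine nitrogen

A few compounds are considered here, and "the series" means these few. Any claim that something is new, unique, unknown or untested is made for them only; others in the source may bear on it.

Compound 2 `Nc1ccccc1NC(=O)c1ccc(CSC(=S)N2CCN(c3ccccc3F)CC2)cc1` stands highest of the two numbers in a functional assay on MGC-803 cells (Homo sapiens) for antiproliferative activity, read by CCK-8 assay, with a stated time of 72 h, tested at 2 uM (a lower number here means a weaker effect, a higher number a stronger effect of the compound at the concentration tested), where compound 2 gives 33.7%. Its neighbour, compound 1 `Nc1ccccc1NC(=O)c1ccc(CSC(=S)N2CCN(c3ccc(F)cc3)CC2)cc1`, gives 18.8% in this assay, and the step of a number 14.9 percentage points higher from compound 1 to compound 2 (beyond the scatter) is the only measured one. Compound 3 `Nc1ccccc1NC(=O)c1ccc(CSC(=S)N2CCN(c3cnccn3)CC2)cc1` carries the change (pyrazin-2-yl in place of 2-fluorophenyl on an amine nitrogen in a ring). Going by the values given here, the one measured step concerns fluorine placement on the same ring and gives no direct guide to a heteroaryl ring, so a decline toward the level of compound 1 is expected, with wide uncertainty. Compound 3 is estimated at 24%, within 8% to 42%, an expected step of a number 9.7 percentage points lower from compound 2 to compound 3 (within the scatter).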

Compound 3, a percentage reported as inhibition, at one concentration (the size of the read-out at that concentration, not a potency): 27.1%
Beside the measured number, compound 3's estimate is 3.1 percentage points below it, within the range that was stated.
By their numbers in this assay, from the lowest: compounds 1, 3 and 2 (each within the scatter of the next, the first and the last beyond it).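

Pyrazin-2-yl, the first ring here that is not carbon-only, keeps the read-out within the scatter of both fluorophenyl compounds in this assay: replacing 2-fluorophenyl gives a number 6.6 percentage points lower from compound 2 to compound 3 (within the scatter), and replacing 4-fluorophenyl gives a number 8.3 percentage points higher from compound 1 to compound 3 (within the scatter). At this amine nitrogen in a ring, the change therefore shows no loss or gain that can be told from the scatter. No supporting data bear on this result. As far as these compounds go, whether a pyridin-2-yl, an unsubstituted phenyl or a small alkyl group such as methyl would hold the same level remains open.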